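The source may hold more compounds than are shown below. What is called first, only, known or untested is meant among the compounds shown, and "the series" means these compounds.

Compound 3 `O=C(Nc1ccc(Cl)c(-c2nnc3c(Cl)cccn23)c1)c1cccnc1Cl` carries a 2-chloropyridin-3-yl group on the carbonyl carbon of the shared core. In a functional assay on MDA-MB-231 cells (Homo sapiens) for antiproliferative activity, read by MTT assay, with stated times of 72 h and 4 h (a higher number here means a weaker inhibitor, a lower number a stronger inhibitor), compound 3 gives 89700 nM; of the two numbers recorded it is the larger, but compound 2 `O=C(Nc1ccc(Cl)c(-c2nnc3c(Cl)cccn23)c1)c1cccc(Cl)c1` sits close by at 66100 nM, and the gap a 1.4-fold higher number from compound 2 to compound 3 (0.13 log units; within the scatter) lies within the scatter. Compound 1 `O=C(Nc1ccc(Cl)c(-c2nnc3c(Cl)cccn23)c1)c1ccc(Cl)cc1` returns only a limit of the assay in this assay, > 100000 nM (the limit of > 100000 nM in this assay, at which 1 of the 3 values shown sits). Compound 4 `O=C(Nc1ccc(Cl)c(-c2nnc3c(Cl)cccn23)c1)c1ccccc1` differs from compound 3 by phenyl in place of 2-chloropyridin-3-yl on a carbonyl carbon. The steps already measured at this position were all small: an at least 1.5-fold lower number from compound 1 to compound 2 (0.17 log units; that floor lies within the scatter) and an at least 1.1-fold lower number from compound 1 to compound 3 (0.04 log units; that floor lies within the scatter), each with a floor inside the scatter, and a 1.4-fold higher number from compound 2 to compound 3 (0.13 log units; within the scatter). Every exchange of the ring on the carbonyl carbon so far has moved the number little, so for compound 4 no step beyond the scatter is expected in this assay, and a further limit cannot be ruled out. The estimate for compound 4 is therefore 90000 nM, with a range from 40000 nM to 200000 nM, which means an expected step of a 1.0-fold higher number from compound 3 to compound 4 (0.00 log units; within the scatter).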

Compound 4, half-maximal inhibitory concentration: 58200 nM
Compound 4: the middle estimate sits 1.5-fold (0.19 log units) above what was measured, within the range that was stated.
By their numbers in this assay, from the lowest: compounds 4, 2 and 3 (each within the scatter of the next). At a limit, above all of these: compound 1.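

With phenyl on the carbonyl carbon, the ring carries neither a chloro group nor a ring nitrogen, and in this assay the exchange for 2-chloropyridin-3-yl gives a 1.5-fold lower number from compound 3 to compound 4 (0.19 log units; within the scatter), while the exchange of chloro for hydrogen on the 3-chlorophenyl ring gives a 1.1-fold lower number from compound 2 to compound 4 (0.06 log units; within the scatter), so neither removal moves the number beyond the scatter. The same exchange on the 4-chlorophenyl ring gives an at least 1.7-fold lower number from compound 1 to compound 4 (0.23 log units; that floor lies within the scatter), which is a floor and not a measured step. Compound 1 remains a limit of the assay and not a number: the limit of > 100000 nM in this assay, at which 1 of the 4 values shown sits.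

The rings shown on the carbonyl carbon are all six-membered and aromatic, so it stays open whether an amine, a carboxylic acid or a longer alkyl chain there would move the number beyond the scatter. Going by these compounds, the effect of changes elsewhere on the shared core also stays open.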